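A few compounds are considered here, and "the series" means these few. Any claim that something is new, unique, unknown or untested is made for them only; others in the source may bear on it.

Working notes on the series. Compound 3 `CC(C)(C)c1ccc(NC(=O)c2ccc(-c3ncccc3N(S(C)(=O)=O)S(C)(=O)=O)cc2)cc1` gives 0.8 nM in a functional assay for antagonist activity at transient receptor potential cation channel subfamily V member 1 (Homo sapiens), read by FLIPR (a lower number here means a stronger inhibitor, a higher number a weaker inhibitor), the lowest of the two numbers obtained so far. Compound 2 `CC(C)(C)c1ccc(NC(=O)c2ccc(-c3ncccc3NC3CCCC3)cc2)cc1` gives 190 nM in this assay. Compound 1 `O=C(Nc1ccccc1)c1ccc(-c2ncccc2C(F)(F)F)cc1` gives only a limit of > 4000 nM in this assay; this is a limit of the assay and not a number, and one of the three values shown sits there (the limit of > 4000 nM in this assay, at which 1 of the 3 values shown sits).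

Compound 4 `CC(C)(C)c1ccc(NC(=O)c2ccc(-c3ncccc3-c3nnco3)cc2)cc1` is not yet measured. It differs from compound 3 by 1,3,4-oxadiazol-2-yl in place of bis(methylsulfonyl)amino on an aromatic carbon. Among the compounds with values here, one measured step bears on this aromatic carbon: a 240-fold lower number from compound 2 to compound 3 (2.38 log units; beyond the scatter). Within the data shown here, that step shows the group at this carbon moving the number over a wide span, but neither cyclopentylamino nor bis(methylsulfonyl)amino resembles the entering five-membered aromatic ring, and no measured pair shows such a ring in this place. The bis(methylsulfonyl)amino group of compound 3 carries the strongest value shown, so a move away from it toward a smaller group with fewer acceptors is expected to raise the number, though less than the full distance back to compound 2. A step of a 38-fold higher number from compound 3 to compound 4 (1.57 log units; beyond the scatter) is therefore expected. Compound 4 is estimated at 30 nM in this assay, with a likely range from 3 nM to 300 nM.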

Compound 4, half-maximal inhibitory concentration: 91 nM
The estimate for compound 4 lay 3.0-fold (0.48 log units) below the measured number; the measured number falls inside the stated range.
By their numbers in this assay, from the lowest: compound 3; then compound 4; then compound 2. At a limit, above all of these: compound 1.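

At this aromatic carbon, 1,3,4-oxadiazol-2-yl in place of bis(methylsulfonyl)amino gives a 110-fold higher number from compound 3 to compound 4 (2.06 log units; beyond the scatter) in this assay, so the low number of compound 3 does not carry over to a five-membered aromatic ring with 3 hetero atoms. Both groups in that change carry 0 hydrogen-bond donors and no net charge, and both carry hydrogen-bond acceptors, so these shared features alone do not hold the number down. Set against cyclopentylamino, the same ring gives only a 2.1-fold lower number from compound 2 to compound 4 (0.32 log units; beyond the scatter), a modest step, which leaves bis(methylsulfonyl)amino as the one group among these three at this carbon that reaches the low number of compound 3.

From the compounds shown here alone, whether a single methylsulfonylamino group, a simple acetamide or a nitrile at this carbon would give a number closer to that of compound 3 or to that of compound 4 remains open, as does how much of the effect needs both methylsulfonyl groups. Nothing shown here measures what lies behind the size of these steps.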